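Adding a 4-Fluorophenyl to the Most Soluble Analogue

The compounds below may be only part of what the source reports. "The series", "measured", "known", "first", "only" and "open" are said of these compounds alone.

Three compounds share an amide-linked diphenylpropanoyl or diphenylmethyl motif on a piperazine core. In a physicochemical assay for solubility, at pH 7.4 (a lower number here means a less soluble compound, a higher number a more soluble compound), compound 1 `O=C(CC(c1ccccc1)c1ccccc1)N1CCN(C(c2ccccc2)c2cccc(Cl)c2)CC1` gives 0.37 ug/mL, and in this assay compound 2 `O=C(NC(c1ccccc1)c1ccccc1)N1CCN(C(c2ccccc2)c2ccccc2)CC1` gives 0.38 ug/mL. Compound 3 `CN1CCC(CN2CCN(C(=O)CC(c3ccccc3)c3ccccc3)CC2)CC1` stands apart: in this assay compound 3 gives 151 ug/mL, the highest of the three numbers, beyond the scatter above both compound 2 and compound 1.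

Compound 4 `CN1CCC(C(c2ccc(F)cc2)N2CCN(C(=O)CC(c3ccccc3)c3ccccc3)CC2)CC1` differs from compound 3 in one place: 4-fluorophenyl in place of hydrogen on a saturated chain carbon bound to an amine nitrogen in a ring and a saturated ring carbon. Among the compounds with values here, no step between measured compounds maps this change, so the expectation rests on where the three numbers lie. Compound 4 keeps the methylpiperidine of compound 3 but gains an aromatic ring, moving its make-up towards that of compound 1 and compound 2, whose values in this assay sit far below compound 3. A step downward, beyond the scatter, is therefore expected from compound 3 to compound 4, of the size a 19-fold lower number from compound 3 to compound 4 (1.28 log units; beyond the scatter), though not all the way to the level of compound 1 and compound 2. For compound 4 the estimated solubility in this assay is 8 ug/mL, with a range from 1 ug/mL to 50 ug/mL.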

Compound 4, solubility: 72.7 ug/mL
Compound 4: the middle estimate sits 9.1-fold (0.96 log units) below what was measured; the measured number lies above the stated range.
By their numbers in this assay, from the lowest: compounds 1 and 2 (each within the scatter of the next); then compound 4; then compound 3.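

At the saturated chain carbon bound to an amine nitrogen in a ring and a saturated ring carbon, 4-fluorophenyl in place of hydrogen gives a 2.1-fold lower number from compound 3 to compound 4 (0.32 log units; beyond the scatter) in this assay, a modest change. Within the data shown here, no earlier pair of compounds differed in one place, so this is the first direct reading of a single change, and it shows that this carbon can carry an added aromatic ring while compound 4 still gives 72.7 ug/mL. Nothing shown here bears on why the step has this size.

Going by these compounds, how an unsubstituted phenyl or a methyl at this same carbon would compare remains open, as does how much of the step belongs to the aromatic ring and how much to its fluorine. Also open, on these data alone, is whether 4-fluorophenyl at this place would give a step of similar size in a compound that carries a carboxylic acid or a hydroxyl group instead of the methylpiperidine.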